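A new amide on a weak antagonist scaffold

The source may hold more compounds than are shown below. What is called first, only, known or untested is meant among the compounds shown, and "the series" means these compounds.

Two compounds share a core carrying a nitrile and a benzyl or aroyl amine. Compound 1 `CC(C)c1cc(C(=O)N2CCc3c(sc(NC(=O)c4ccc(Cl)cc4)c3C#N)C2)[nH]n1` gives 12200 nM in a functional assay on Chem-3 cells for antagonist activity at metabotropic glutamate receptor 1 (Homo sapiens), read by fluorescence and calcium flux; on this read-out lower numbers stand for stronger inhibition and higher numbers for weaker inhibition. Compound 2 `CC(C)c1cc(C(=O)N2CCc3c(sc(NCc4ccccc4)c3C#N)C2)[nH]n1` gives 43200 nM in this assay, the highest of the two numbers, with a 3.5-fold higher number from compound 1 to compound 2 (0.55 log units; beyond the scatter). Compound 3 `N#Cc1c(NCc2ccccc2)sc2c1CCN(C(=O)c1ccc(F)cc1)C2` differs from compound 2 by 4-fluorophenyl in place of 3-isopropyl-1H-pyrazol-5-yl on a carbonyl carbon. Among the measured compounds shown here, no measured step touches this position, so no direction can be drawn from the two values; the outcome is uncertain. Compound 3 is therefore expected near 40000 nM in this assay, within 10000 nM to 150000 nM, meaning a 1.1-fold lower number from compound 2 to compound 3 (0.03 log units; within the scatter).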

Compound 3, half-maximal inhibitory concentration: 600 nM
Compound 3: middle estimate off by 67-fold (1.82 log units), on the high side, and the stated range ends above it.
By their numbers in this assay, from the lowest: compound 3; then compound 1; then compound 2.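

The group on the carbonyl carbon, whose other neighbour is the amide-type nitrogen in a ring, proves a strong control on activity in this assay: 4-fluorophenyl in place of 3-isopropyl-1H-pyrazol-5-yl gives a 72-fold lower number from compound 2 to compound 3 (1.86 log units; beyond the scatter). The gain comes with the loss of the pyrazole's hydrogen-bond donor and acceptor, but this single step cannot separate those from the ring change or the fluorine. Nothing available explains the gain.

Going by these compounds, whether the fluorine matters remains open, since a plain phenyl or a 4-methoxyphenyl on this carbonyl would test it. Also open, on these data alone, is whether the gain carries over to the (4-chlorophenyl)carbonyl amine of compound 1.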